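This account rests on a few compounds, and the source may have more. Where it says the series, first, only, none or still open, it means among the compounds named here.

Compound 1 `CCc1cccc2ccc(-c3ccc(C(/C=C4\OC(=O)NC4=O)(CC)CC)c(=O)[nH]3)cc12`: 17 nM
Compound 2 `CC(C)[C@@H](c1ccc(-c2ccc3cccc(F)c3c2)[nH]c1=O)[C@@H]1OC(=O)NC1=O`: 85 nM
Compound 3 `CCC(/C=C1\OC(=O)NC1=O)(CC)c1ccc(-c2ccc3cccc(F)c3c2)[nH]c1=O`: 13 nM

All three numbers come from an assay on membranes from Chem-1 cells for displacement of a labelled ligand from prostaglandin E2 receptor EP3 subtype (Homo sapiens), read by scintillation counting, with a stated time of 2 h; on this read-out lower numbers stand for stronger inhibition and higher numbers for weaker inhibition. Among them compound 3 has the lowest number. Compound 1 stands nearest to it, and the gap between the two is within the scatter, so they cannot be told apart on these data. Compound 2 stands furthest away, beyond the scatter.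

Compound 4 `CCC(/C=C1\OC(=O)NC1=O)(CC)c1ccc(-c2ccc3cccc(C(C)C)c3c2)[nH]c1=O` has not yet been measured. It differs from compound 3 in one place: isopropyl in place of fluoro on an aromatic carbon. Going by the values given here, one measured step bears on this change, the exchange of ethyl for fluoro on the same aromatic carbon, a 1.3-fold lower number from compound 1 to compound 3 (0.12 log units; within the scatter). That step stayed within the scatter, and the present one again swaps a small group for a small group on that carbon. A step of similar size is therefore expected, with no change beyond the scatter, as a 1.2-fold higher number from compound 3 to compound 4 (0.06 log units; within the scatter). For compound 4 in this assay the estimate is 15 nM, with a range from 6 nM to 40 nM.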

Compound 4, inhibition constant: 120 nM
Beside the measured number, compound 4's estimate is 8.0-fold (0.90 log units) below it; measured number above the stated range.
By their numbers in this assay, from the lowest: compounds 3 and 1 (each within the scatter of the next); then compounds 2 and 4 (each within the scatter of the next).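

In this assay, this aromatic carbon turns out not to accept every small group equally: isopropyl in place of fluoro gives a 9.2-fold higher number from compound 3 to compound 4 (0.97 log units; beyond the scatter). The change from ethyl is also slight on paper, a methyl in place of hydrogen on the saturated chain carbon bound to the ring, yet it gives a 7.1-fold higher number from compound 1 to compound 4 (0.85 log units; beyond the scatter), so the tolerance shared by fluoro and ethyl does not extend to isopropyl in this series. Nothing available explains why this added methyl carries such a cost.

As far as these compounds go, it remains open how a plain hydrogen, a methoxy group or a chlorine would behave on this carbon. It is also unknown whether a tert-butyl group or a longer chain such as propyl would raise the number further or whether a cyclopropyl ring would fare differently.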